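A few compounds are considered here, and "the series" means these few. Any claim that something is new, unique, unknown or untested is made for them only; others in the source may bear on it.

Measured so far:
- compound 1 `Cc1ccccc1N1C(=O)/C(=C/c2ccc(OCC(=O)Nc3ccc(C(=O)O)cc3)cc2)SC1=S` — in an assay on isolated protein for inhibition of Apoptosis regulator Bcl-2 (Homo sapiens), read by fluorescence polarization (on this read-out higher numbers stand for weaker inhibition and lower numbers for stronger inhibition), compound 1 gives > 10000 nM, which is a limit of the assay and not a number.
- compound 2 `O=C(COc1ccc(/C=C2\SC(=S)N(c3ccc([N+](=O)[O-])cc3)C2=O)cc1)Nc1ccc(C(=O)O)cc1` — in this assay compound 2 gives > 10000 nM, likewise a limit.
- compound 3 `Cc1cccc(N2C(=O)/C(=C/c3ccc(OCC(=O)Nc4ccc(C(=O)O)cc4)cc3)SC2=S)c1` — in this assay compound 3 gives > 10000 nM, again a limit.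

Compound 3 therefore stands at the limit of > 10000 nM in this assay, at which 3 of the 3 values shown sit, together with the other two compounds. The three changes on the amide-type nitrogen in the ring give a step that the two limits leave unreadable from compound 1 to compound 2, a step that the two limits leave unreadable from compound 1 to compound 3 and a step that the two limits leave unreadable from compound 2 to compound 3; none of them can be read, since every value involved is a limit.

Compound 4 `Cc1cccc(C)c1N1C(=O)/C(=C/c2ccc(OCC(=O)Nc3ccc(C(=O)O)cc3)cc2)SC1=S` carries the next change on the same position: 2,6-dimethylphenyl in place of 3-methylphenyl on an amide-type nitrogen in a ring. Among the measured compounds shown here, no measured step bears on this change in a readable way, and none of the measured compounds has given a number in this assay. The expectation for compound 4 is therefore that it also returns a limit rather than a number, and the step that the limit leaves unreadable from compound 3 to compound 4 is expected to be unreadable for the same reason. Compound 4 is estimated at 15000 nM, with a range from 5000 nM to 50000 nM, the result most likely reported as a limit.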

Compound 4, inhibition constant: 7600 nM
For compound 4 the middle estimate is 2.0-fold (0.30 log units) above the measured one; measured number inside the range.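

In this assay, among the compounds shown here, compound 4 is the first of the series to return a number and not a limit, so this position on the amide-type nitrogen in the ring can now be read with 2,6-dimethylphenyl, whereas 2-methylphenyl, 3-methylphenyl and 4-nitrophenyl all remain at the limit: the limit of > 10000 nM in this assay, at which 3 of the 4 values shown sit. The change gives an at least 1.3-fold lower number from compound 3 to compound 4 (0.11 log units; that floor lies within the scatter), gives an at least 1.3-fold lower number from compound 2 to compound 4 (0.11 log units; that floor lies within the scatter) and gives an at least 1.3-fold lower number from compound 1 to compound 4 (0.11 log units; that floor lies within the scatter). On these data alone, each of these figures is only a floor, so the real size of the change remains unknown, and the steps among compound 1, compound 2 and compound 3 cannot be read.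

The compounds shown leave open how a plain phenyl, a 2,6-dichlorophenyl or a 2,6-diethylphenyl would read at this position, and thus whether the number can move further from the limit. Also open, as far as these compounds go, is how a change elsewhere on the core of compound 4 would read, such as a methyl ester or a tetrazole in place of the carboxylic acid.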